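This account rests on a few compounds, and the source may have more. Where it says the series, first, only, none or still open, it means among the compounds named here.

Measured compounds:
Compound 1, `CC(C)CN(c1ccc(F)cc1)S(=O)(=O)c1ccc2c(c1)C(O)CC(C1CCOCC1)O2`: 3.39
Compound 2, `CCc1ccc(N(CC(C)C)S(=O)(=O)c2ccc3c(c2)C(OC)CC(C2CCOCC2)O3)cc1`: 4.69
Compound 3, `CCc1ccc(N(CC(C)C)S(=O)(=O)c2ccc(OCC3CCOCC3)c3c2CCC3O)cc1`: 4.55

The read-out here is a physicochemical assay for lipophilicity, at pH 7.4; on this read-out lower numbers stand for lower lipophilicity and higher numbers for higher lipophilicity. Among the three measured compounds, compound 1 gives the lowest number in this assay; the nearest of the others is compound 3, which lies beyond the scatter above it, and the furthest is compound 2, also beyond the scatter above it. Compound 2 and compound 3 differ from compound 1 in more than one place, so none of these gaps can be tied to a single change.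

The unmeasured compound 4, `CC(C)CN(C1CCc2ccc(F)cc21)S(=O)(=O)c1ccc2c(c1)C(O)CC(C1CCOCC1)O2`, differs from compound 1 in one place: 6-fluoro-2,3-dihydro-1H-inden-1-yl in place of 4-fluorophenyl on a sulfonamide nitrogen. The entering group keeps the fluorine and the six-membered aromatic ring of carbon only and adds a five-membered non-aromatic ring of carbon only, with no change in hydrogen-bond donors, acceptors or charge.

Going by the values given here, with no measured pair showing this exact change, the expectation rests on the change itself. Adding a carbon-only ring to a group on a sulfonamide nitrogen is expected to raise the number in this assay by a moderate step, beyond the scatter. Compound 4 is therefore expected to give 4.1 in this assay, within 3.6 to 4.6, an estimated step of a number 0.71 log units higher from compound 1 to compound 4 (beyond the scatter).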

Compound 4, distribution coefficient: 3.94
Beside the measured number, compound 4's estimate is 0.16 log units above it; the measured number falls inside the stated range.
By their numbers in this assay, from the lowest: compound 1; then compound 4; then compounds 3 and 2 (each within the scatter of the next).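

In this assay, the change of group on a sulfonamide nitrogen, from 4-fluorophenyl to 6-fluoro-2,3-dihydro-1H-inden-1-yl, gives a number 0.55 log units higher from compound 1 to compound 4 (beyond the scatter). Going by these compounds alone, this is the first pair here that differs in one place, so a gap in this read-out can now be tied to a single change, showing that the group on this nitrogen can shift the number on its own, by a modest step, while the fluorine, the six-membered aromatic ring, the hydrogen-bond donor and acceptor counts and the net charge of the group all stay the same. The data contain no measurement that explains why the number moves with this change.

From the compounds shown here alone, this single step comes from one pair on one core, so it remains open whether the same swap would give a similar step on the different cores of compound 2 or compound 3. Also open, going by these compounds, is how other groups on this sulfonamide nitrogen, such as a saturated cyclohexyl ring, a longer carbon chain or a chain ending in an amine, would compare in this assay.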